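Working notes: isopropyl in place of cyclohexyl

A few compounds are considered here, and "the series" means these few. Any claim that something is new, unique, unknown or untested is made for them only; others in the source may bear on it.

Measured in a functional assay on DU-145 cells (Homo sapiens) for cytotoxicity, read by MTT assay, with a stated time of 72 h; on this read-out higher numbers stand for an effect only at larger amounts of compound and lower numbers for an effect already at smaller amounts:
- compound 1 `COc1cccc(Nc2cc(-c3ccccc3)oc(=O)c2)c1`: 0.66 uM
- compound 2 `COc1ccc(Nc2cc(C3CCCCC3)oc(=O)c2)cc1`: 8.61 uM
- compound 3 `O=c1cc(Nc2ccccc2)cc(-c2ccccc2)o1`: 0.098 uM

Compound 2 gives the highest of the three numbers, beyond the scatter from both other compounds. Compound 4 `COc1ccc(Nc2cc(C(C)C)oc(=O)c2)cc1` carries isopropyl in place of cyclohexyl on an aromatic carbon. Among the compounds with values here, no measured step covers this change. Within the data shown here, the only single-place step, a 6.7-fold lower number from compound 1 to compound 3 (0.83 log units; beyond the scatter), is modest and concerns hydrogen in place of methoxy, so it offers only a rough scale. No step beyond the scatter is therefore expected in this assay, with a slight lean towards a higher number. The expected step is a 1.4-fold higher number from compound 2 to compound 4 (0.14 log units; within the scatter). For compound 4 the estimated value is 12 uM, with an expected range of 3.5 uM to 40 uM.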

Compound 4, concentration for half-maximal effect: > 30 uM
Compound 4: a limit, no number; the forecaster's own chance of this, stated with the estimate: 10%; middle value at least 2.5-fold (0.39 log units) away from the limit.
By their numbers in this assay, from the lowest: compound 3; then compound 1; then compound 2. At a limit, above all of these: compound 4.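

At this position, next to the ring oxygen, the change from cyclohexyl to isopropyl is not neutral in this assay (an at least 3.4-fold higher number from compound 2 to compound 4 (0.54 log units; beyond the scatter)), and the step is beyond the scatter. Within the data shown here, the only earlier step concerned hydrogen in place of methoxy, so this is the first reading of how the group at this position affects the number. Of compound 4 only a limit is known: the limit of > 30 uM in this assay, at which 1 of the 4 values shown sits.

Going by these compounds, how far compound 4 lies past that limit stays open. Also open, on these data alone, is whether a longer chain, an amine or a carboxylic acid at this position would give a lower number than isopropyl.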